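Bromo for chloro: from compound 2 to compound 3

A few compounds are considered here, and "the series" means these few. Any claim that something is new, unique, unknown or untested is made for them only; others in the source may bear on it.

In an in vitro ADME assay on microsomes from liver (Mus musculus) for pharmacokinetics, read by LC-MS, with a stated time of 10 min, tested at 1 uM (on this read-out higher numbers stand for fast clearance and lower numbers for slow clearance), compound 1 `CN1C[C@H](C(=O)Nc2ccc(F)cc2)[C@@H](c2ccc(/C=C/C(=O)Nc3ccccc3N)cc2)C1` gives 34 mL/min/kg and compound 2 `CN1C[C@H](C(=O)Nc2ccc(F)c(Cl)c2)[C@@H](c2ccc(/C=C/C(=O)Nc3ccccc3N)cc2)C1` gives 34 mL/min/kg, which leaves compound 2 level with compound 1. Compound 3 `CN1C[C@H](C(=O)Nc2ccc(F)c(Br)c2)[C@@H](c2ccc(/C=C/C(=O)Nc3ccccc3N)cc2)C1` has bromo in place of chloro on an aromatic carbon, ortho to a fluoro group: bromo in place of chloro on an aromatic carbon. For the measured compounds named here, only one measured step bears on this change: no change at the digits printed from compound 1 to compound 2 (within the scatter), with chloro in place of hydrogen on an aromatic carbon. That single step gives no reason to expect a shift beyond the scatter. The step expected in this assay is no change at the digits printed from compound 2 to compound 3 (within the scatter). Compound 3 is estimated at 34 mL/min/kg, with an expected range of 19 mL/min/kg to 60 mL/min/kg.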

Compound 3, clearance: 43 mL/min/kg
The estimate for compound 3 lay 1.3-fold (0.10 log units) below the measured number; low and high end bracket the measured number.
By their numbers in this assay, from the lowest: compounds 1, 2 and 3 (each within the scatter of the next).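

Bromo in place of chloro, ortho to a fluoro group, gives a 1.3-fold higher number from compound 2 to compound 3 (0.10 log units; within the scatter) in this assay while bromo in place of hydrogen gives a 1.3-fold higher number from compound 1 to compound 3 (0.10 log units; within the scatter) on the same read-out. For the compounds shown here, a second, larger halogen thus also stays within the scatter at this position, where the earlier compounds covered only chloro. No measurement here offers an explanation for these steps.

As far as these compounds go, whether an amine, a methoxy group or a carboxylic acid at this position would move clearance beyond the scatter remains open. So does the outcome of these halogens without the fluoro group.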